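The compounds below may be only part of what the source reports. "The series", "measured", "known", "first", "only" and "open" are said of these compounds alone.

Compound 1 `N#Cc1c(-c2ccc(F)cc2)nc2c(c(-c3ccccc3)nn2-c2ccccc2)c1-c1ccc(O)cc1`: 10200 nM
Compound 2 `N#Cc1c(-c2ccc(Cl)cc2)nc2c(c(-c3ccccc3)nn2-c2ccccc2)c1-c1ccc(O)cc1`: 20800 nM

Both compounds were tested in a functional assay on K562 cells (Homo sapiens) for antiproliferative activity, read by resazurin assay, with a stated time of 72 h; a higher number here means a weaker inhibitor, a lower number a stronger inhibitor. For the measured compounds named here, compound 2 has the highest of the two numbers; its nearest neighbour is compound 1, and the step of a 2.0-fold higher number from compound 1 to compound 2 (0.31 log units; beyond the scatter) is the only measured step, a modest one that arises from chloro in place of fluoro on an aromatic carbon.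

Compound 3 `N#Cc1c(-c2cccs2)nc2c(c(-c3ccccc3)nn2-c2ccccc2)c1-c1ccc(O)cc1` differs from compound 2 by thiophen-2-yl in place of 4-chlorophenyl on an aromatic carbon. Going by the values given here, no measured step bears directly on this change: the one step available, from compound 1 to compound 2, exchanges one halogen for another on the same aromatic ring and leaves that ring in place, whereas here the whole 4-chlorophenyl group gives way to thiophen-2-yl. That step shows only a modest shift from one substituent to another at this position, so a large move in this assay is not expected; compound 3 is estimated to land close to compound 2, with the step of a 1.6-fold lower number from compound 2 to compound 3 (0.20 log units; within the scatter) expected to stay near the scatter. On that basis compound 3 is estimated at 13000 nM, within a range of 4000 nM to 40000 nM.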

Compound 3, half-maximal inhibitory concentration: 11600 nM
Estimate against measurement, compound 3: 1.1-fold (0.05 log units) above, within the range that was stated.
By their numbers in this assay, from the lowest: compounds 1, 3 and 2 (each within the scatter of the next, the first and the last beyond it).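

In this assay, the position next to the ring nitrogen and ortho to the cyano group has now been probed by replacing the whole ring rather than only its halogen, and the number stays within the scatter of both earlier compounds: thiophen-2-yl in place of 4-chlorophenyl gives (a 1.8-fold lower number from compound 2 to compound 3 (0.25 log units; within the scatter)), and thiophen-2-yl in place of 4-fluorophenyl gives (a 1.1-fold higher number from compound 1 to compound 3 (0.06 log units; within the scatter)). Among these three compounds, then, a five-membered aromatic ring with one sulfur serves here about as well as a six-membered aromatic ring of carbon only, and thiophen-2-yl cannot be ordered against either halogen-bearing phenyl group, even though those two groups differ from each other beyond the scatter. Nothing measured alongside these numbers explains why the exchange leaves the number in place.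

From the compounds shown here alone, all three compounds carry an aromatic ring at this position, so it remains open how the antiproliferative number would respond to a group without one, such as a morpholine ring, a primary amine or a short alkyl chain. The 4-hydroxyphenyl group is also the same throughout, so the compounds shown say nothing about whether a methoxy group in place of its hydroxyl would change the picture.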